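Methyl on the phenyl ring: from compound 1 to compound 3

This account rests on a few compounds, and the source may have more. Where it says the series, first, only, none or still open, it means among the compounds named here.

Measured so far:
compound 1 `CS(=O)(=O)c1ccc(-c2cnc3[nH]cc(-c4nnc(-c5ccccc5)o4)c(=O)c3c2)cc1` — 15.7%
compound 2 `N#Cc1ccc(-c2cnc3[nH]cc(-c4nnc(-c5ccc(Cl)cc5)o4)c(=O)c3c2)cc1` — 18.3%

In a functional assay on HCT-116 cells (Homo sapiens) for inhibition, read by MTT assay, with a stated time of 24 h, tested at 10 uM (on this read-out lower numbers stand for less inhibition of growth and higher numbers for more inhibition of growth at the one concentration tested), compound 1 gives 15.7%, at the low end of the two numbers shown; compound 2 gives 18.3%, which lies within the scatter of compound 1, so the two cannot be told apart. Both sit at modest growth inhibition at the single concentration tested.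

Compound 3 `Cc1cccc(-c2nnc(-c3c[nH]c4ncc(-c5ccc(S(C)(=O)=O)cc5)cc4c3=O)o2)c1` differs from compound 1 by methyl in place of hydrogen on an aromatic carbon. Within the data shown here, no pair of measured compounds shares this change, so its size is unknown from the data. The two measured compounds differ in two places and still land close together, which gives no sign that small peripheral changes move this read-out. A step no larger than the scatter is expected for a number 2.3 percentage points higher from compound 1 to compound 3 (within the scatter), in no particular direction. Compound 3 is therefore estimated at 18%, with a range from 6% to 34%.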

Compound 3, percent growth inhibition at one concentration: 25.2%
Compound 3: middle estimate off by 7.2 percentage points, on the low side, within the range that was stated.
By their numbers in this assay, from the lowest: compounds 1, 2 and 3 (each within the scatter of the next).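

Phenyl to 3-methylphenyl is the first single-place change that can be read in this assay and gives a number 9.5 percentage points higher from compound 1 to compound 3 (within the scatter) so the two compounds cannot be told apart. This position on the phenyl ring therefore accepts methyl in place of hydrogen, meta to a large group, with a step no larger than the scatter on this read-out. Nothing measured here bears on the reason for the size of this step.

As far as these compounds go, whether a longer chain such as propyl, an amine or a carboxylic acid at this carbon would give a step beyond the scatter remains open. Also open, from the compounds shown here alone, is whether methyl at the other carbons of the phenyl ring would behave in the same way.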